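This account rests on a few compounds, and the source may have more. Where it says the series, first, only, none or still open, it means among the compounds named here.

Compound 1 `CSc1nc(C)nc(SC)c1NC(=O)N(Cc1ccc(Oc2ccc(F)cc2)cc1)C1CCCCCC1` belongs to a small set of three ureas built on one shared core, and in an assay for inhibition of acyl-CoA:cholesterol acyltransferase (Oryctolagus cuniculus), using microsomes (a lower number here means a stronger inhibitor, a higher number a weaker inhibitor), compound 1 gives 56 nM. Its two neighbours carry a different aryl group on the same amide-type nitrogen: compound 2 `COc1cc(C)nc(OC)c1NC(=O)N(Cc1ccc(Oc2ccc(F)cc2)cc1)C1CCCCCC1` gives 33 nM, and compound 3 `Cc1cc(S(C)(=O)=O)c(NC(=O)N(Cc2ccc(Oc3ccc(F)cc3)cc2)C2CCCCCC2)c(Cl)n1` gives 30 nM. Compound 1 thus shows the highest of the three numbers, yet the moves away from it, a 1.7-fold lower number from compound 1 to compound 2 (0.23 log units; within the scatter) and a 1.9-fold lower number from compound 1 to compound 3 (0.27 log units; within the scatter), both lie within the scatter, as does a 1.1-fold lower number from compound 2 to compound 3 (0.04 log units; within the scatter).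

Compound 4 `Cc1ccc(NC(=O)N(Cc2ccc(Oc3ccc(F)cc3)cc2)C2CCCCCC2)c(Cl)n1` is not yet measured. Its change from compound 1 is a group of 8 heavy atoms (6 carbon, 1 nitrogen, 1 chlorine; one six-membered aromatic ring with 1 hetero atom) in place of a group of 11 heavy atoms (7 carbon, 2 nitrogen, 2 sulfur; one six-membered aromatic ring with 2 hetero atoms), on an amide-type nitrogen. Both measured steps that bear on this, the swap to compound 2 and the swap to compound 3, alter the same aryl group on that nitrogen and stay within the scatter. On that basis no step beyond the scatter is expected in this assay, though the incoming 2-chloro-6-methylpyridin-3-yl group is the smallest of the aryl groups tried, so the estimate leans slightly toward a higher number. Compound 4 is therefore estimated at 80 nM, within a range of 25 nM to 250 nM, which means an expected step of a 1.4-fold higher number from compound 1 to compound 4 (0.15 log units; within the scatter).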

Compound 4, half-maximal inhibitory concentration: 19 nM
Compound 4: the middle estimate sits 4.2-fold (0.62 log units) above what was measured; the whole stated range lies above it.
By their numbers in this assay, from the lowest: compounds 4, 3, 2 and 1 (each within the scatter of the next, the first and the last beyond it).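

In this assay, within the data shown here, the 2-chloro-6-methylpyridin-3-yl group on the amide-type nitrogen gives the first step at this position that passes the scatter (a 2.9-fold lower number from compound 1 to compound 4 (0.47 log units; beyond the scatter)), and it carries fewer heavy atoms and fewer hydrogen-bond acceptors than the group it replaces. The other two steps stay within the scatter (a 1.6-fold lower number from compound 3 to compound 4 (0.20 log units; within the scatter); a 1.7-fold lower number from compound 2 to compound 4 (0.24 log units; within the scatter)), so hydrogen in place of methylsulfonyl on an aromatic carbon leaves the number unchanged within that scatter, and this smaller group matches compound 2 and compound 3 within the same limits. Nothing measured here explains the gain over compound 1.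

From the compounds shown here alone, it remains open whether an amine or a carboxylic acid in place of the chlorine or the methyl on this group would keep the number. The compounds shown also leave open how changes elsewhere on the shared core would act.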